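Amide variation notes, inhibition after oral dosing

A few compounds are considered here, and "the series" means these few. Any claim that something is new, unique, unknown or untested is made for them only; others in the source may bear on it.

Measured compounds in an assay on the whole organism (plasma, strain Sprague-Dawley) for inhibition of Dipeptidyl peptidase 4 (Rattus norvegicus), with a stated time of 10 h, at a dose of 1 mg/kg by the oral route; a higher number here means more inhibition at the dose given (going by the name of the read-out), a lower number less inhibition:
compound 1, `CCCNC(=O)[C@@H]1CN[C@H](C(=O)N2CCC[C@H]2C#N)C1`, gives 21%
compound 2, `CCNC(=O)[C@@H]1CN[C@H](C(=O)N2CCC[C@H]2C#N)C1`, gives 19%
compound 3, `CN(C)C(=O)[C@@H]1CN[C@H](C(=O)N2CCC[C@H]2C#N)C1`, gives 52%

All three share one core and differ only at the amide on the carbonyl carbon. Compound 2 and compound 1 differ by methyl in place of hydrogen on a saturated chain carbon, two bonds along the chain from an amide-type nitrogen; the step of a number 2 percentage points higher from compound 2 to compound 1 (within the scatter), so the two values tell nothing apart. Compound 2 and compound 3 differ by dimethylamino in place of ethylamino on a carbonyl carbon, and here the step is a number 33 percentage points higher from compound 2 to compound 3 (beyond the scatter); the related step of a number 31 percentage points higher from compound 1 to compound 3 (beyond the scatter) points the same way. Compound 3 thus stands highest of the three, with both others beyond the scatter below it.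

Compound 4, `CCN(C)C(=O)[C@@H]1CN[C@H](C(=O)N2CCC[C@H]2C#N)C1`, is not yet measured. It differs from compound 3 by methyl in place of hydrogen on a saturated chain carbon bound to an amide-type nitrogen. This is the same kind of change as that from compound 2 to compound 1, but not the same: there the entering methyl sat on a saturated chain carbon two bonds along the chain from an amide-type nitrogen, whereas in compound 4 it sits on a saturated chain carbon bound to an amide-type nitrogen. The cores of the pairs also differ, as described by the change from compound 2 to compound 3.

For compound 4 the expected step is a number 4 percentage points lower from compound 3 to compound 4 (within the scatter), resting on the flat step a number 2 percentage points higher from compound 2 to compound 1 (within the scatter) for the only comparable methyl addition, though that precedent is a single pair on a different core. The estimate for compound 4 is therefore 48%, expected to fall between 30% and 65%.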

Compound 4, a percentage reported as inhibition, in the whole organism at one dose (the size of the read-out at that dose, not a potency): 34%
The estimate for compound 4 lay 14 percentage points above the measured number; low and high end bracket the measured number.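

On the core of compound 3, methyl in place of hydrogen on a saturated chain carbon bound to an amide-type nitrogen gives a number 18 percentage points lower from compound 3 to compound 4 (beyond the scatter), so a flat result for adding a methyl on the core of compound 2 does not predict the result on the core of compound 3. The comparison in this assay shows that the two steps differ: the same change on two cores in this assay, a number 2 percentage points higher (within the scatter) from compound 2 to compound 1 and a number 18 percentage points lower (beyond the scatter) from compound 3 to compound 4, 20 percentage points apart, beyond the scatter of two such steps

This rests on one pair per core, with the entering methyl placed differently in each, so it gives no general rule for carrying the change and does not separate the effect of the core from that of the methyl's place, while compound 4 remains above both compounds with an amide hydrogen, with a number 15 percentage points higher from compound 2 to compound 4 (beyond the scatter) for methyl in place of hydrogen on an amide-type nitrogen and a number 13 percentage points higher from compound 1 to compound 4 (beyond the scatter) for ethyl(methyl)amino in place of propylamino on a carbonyl carbon.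

The compounds shown leave open whether the downward step continues with diethylamino or with a longer chain on the amide nitrogen. They also leave open how a cyclic amine on the carbonyl carbon, or a carboxylic acid in place of the amide, would compare with compound 3.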